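This account rests on a few compounds, and the source may have more. Where it says the series, first, only, none or still open, it means among the compounds named here.

Compound 3, `COc1ccc2ncc(S(=O)(=O)c3ccc(C)c(Cl)c3)c(N3CCC(C)CC3)c2c1`, is the reference point for this step. Going by the values given here, in an assay on isolated protein for displacement of a labelled ligand from metabotropic glutamate receptor 5 (Homo sapiens), with a stated time of 60 min, tested at 1 uM (a higher number here means more inhibition at the concentration tested (going by the name of the read-out), a lower number less inhibition), compound 3 gives 85%, the highest of the three numbers so far. Compound 1, `COc1ccc2ncc(S(=O)(=O)c3ccc(OC)c(Cl)c3)c(N3CCC(C)CC3)c2c1`, gives 21% in this assay, and compound 2, `COc1ccc2ncc(S(=O)(=O)c3ccc(F)cc3)c(N3CCC(C)CC3)c2c1`, gives 27%. The step of a number 6 percentage points higher from compound 1 to compound 2 (within the scatter) shows that swapping between those two aryl groups changed little, whereas a number 64 percentage points higher from compound 1 to compound 3 (beyond the scatter) and a number 58 percentage points higher from compound 2 to compound 3 (beyond the scatter) are both large rises, so the aryl group on the sulfonyl sulfur clearly matters for this read-out.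

Compound 4, `COc1ccc2ncc(S(=O)(=O)c3cc(Cl)cc(Cl)c3)c(N3CCC(C)CC3)c2c1`, keeps the shared core and the substituted piperidine of compound 3 and differs only in that aryl group: 3,5-dichlorophenyl in place of 3-chloro-4-methylphenyl on a sulfonyl sulfur. The two large steps towards compound 3 bear on this change, since they too alter the aryl on the sulfonyl sulfur, yet none of the three measured aryl groups carries two chlorines, so the size of the new step cannot be read off directly. Since compound 3 holds the top number, a move away from its substitution pattern is expected to cost something, and compound 4 is estimated at 55%, within 25% to 85%, which corresponds to an expected step of a number 30 percentage points lower from compound 3 to compound 4 (beyond the scatter).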

Compound 4, a percentage reported as inhibition, at one concentration (the size of the read-out at that concentration, not a potency): 87%
The estimate for compound 4 lay 32 percentage points below the measured number; the measured number lies above the stated range.
By their numbers in this assay, from the lowest: compounds 1 and 2 (each within the scatter of the next); then compounds 3 and 4 (each within the scatter of the next).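

In this assay, the step of a number 2 percentage points higher from compound 3 to compound 4 (within the scatter) shows that the high read-out at this place on a sulfonyl sulfur does not depend on 3-chloro-4-methylphenyl alone, as 3,5-dichlorophenyl, with the same count of heavy atoms but a second chlorine instead of the methyl, serves equally well. The steps of a number 60 percentage points higher from compound 2 to compound 4 (beyond the scatter) and a number 66 percentage points higher from compound 1 to compound 4 (beyond the scatter) set this new aryl group as clearly apart from the low pair as compound 3 is, so the shown aryl groups now fall into two groups, though a chlorine alone does not mark the high one, since compound 1 carries a chlorine and stands in the low pair. The data offer no explanation for why these two aryl groups read alike.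

The compounds shown leave open how a 3-chlorophenyl, a 3,5-dimethylphenyl or an aryl group bearing an amine or a carboxylic acid would read at this place. These are also readings at a single concentration, so whether compound 3 and compound 4 match in potency as well remains unanswered.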